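From an isobutyl to an ester side chain

This account rests on a few compounds, and the source may have more. Where it says the series, first, only, none or still open, it means among the compounds named here.

Measured compounds:
Compound 1 `COC(=O)c1[nH]c2cc(OC)ccc2c1-c1ccc(Br)cc1`: 330 nM
Compound 2 `COC(=O)c1[nH]c2cc(OC)ccc2c1C(C)C`: > 100000 nM, a limit of the assay
Compound 3 `COC(=O)c1[nH]c2cc(OC)ccc2c1CC(C)C`: 16600 nM

In a functional assay on CCRF-CEM cells (Homo sapiens) for antiproliferative activity, read by MTT assay, with a stated time of 48 h (a higher number here means that more compound is needed for the effect, a lower number that less compound is needed), compound 3 has the higher of the two actual numbers, with a 50-fold higher number from compound 1 to compound 3 (1.70 log units; beyond the scatter). Compound 4 `COC(=O)Cc1c(C(=O)OC)[nH]c2cc(OC)ccc12` carries methoxycarbonyl in place of isopropyl on a saturated chain carbon bound to an aromatic carbon. Among the measured compounds shown here, no measured step makes this exchange. The closest guides are an at least 6.0-fold lower number from compound 2 to compound 3 (0.77 log units; beyond the scatter) and an at least 300-fold higher number from compound 1 to compound 2 (2.48 log units; beyond the scatter), which show large shifts among these side groups. A modest step towards a higher number is therefore expected in this assay, though none beyond the scatter remains possible. The expected change is a 2.4-fold higher number from compound 3 to compound 4 (0.38 log units; beyond the scatter). For compound 4 the estimate is 40000 nM, with an expected range of 12000 nM to 100000 nM.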

Compound 4, half-maximal effective concentration: > 100000 nM
Compound 4 was reported as a limit; the forecaster's own chance of this, stated with the estimate: 40%; at least 2.5-fold (0.39 log units) between middle value and limit.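

In this assay, the only side chain so far to give a measurable number without an aryl group does not tolerate the new ester: methoxycarbonyl in place of isopropyl on a saturated chain carbon bound to an aromatic carbon gives an at least 6.0-fold higher number from compound 3 to compound 4 (0.77 log units; beyond the scatter). Set against the 4-bromophenyl group, (methoxycarbonyl)methyl gives an at least 300-fold higher number from compound 1 to compound 4 (2.48 log units; beyond the scatter). The result for compound 4 is a limit of the assay, not a number.

On these data alone, the step from compound 2 to compound 4 cannot be read, because both compounds stand at the same limit: the limit of > 100000 nM in this assay, at which 2 of the 4 values shown sit. Whether a carboxylic acid, an amide or a longer chain at this place would give a measurable number remains open.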